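Swapping Carboxy for Hydroxy on a Saturated Ring Carbon

This account rests on a few compounds, and the source may have more. Where it says the series, first, only, none or still open, it means among the compounds named here.

Four compounds share one core and differ only at one saturated ring carbon. Compound 1 `COc1ccc(/C=C\c2cc(OC)c(OC)c(OC)c2)cc1OCc1ccc(CN2CC[C@H](C(=O)O)C2)cc1` carries a carboxy group there; compound 2 `COc1ccc(/C=C\c2cc(OC)c(OC)c(OC)c2)cc1OCc1ccc(CN2CC[C@H](O)C2)cc1` carries a hydroxy group in its place, a change counted as hydroxy in place of carboxy on a saturated ring carbon. Compound 3 `COc1ccc(/C=C\c2cc(OC)c(OC)c(OC)c2)cc1OCc1ccc(CN2CC[C@@H](C(=O)O)C2)cc1` has the same atoms and bonds as compound 1 and differs only in configuration as drawn, the core difference being (the two compounds have the same atoms and bonds and differ only in configuration as drawn: 1 of 2 stereo elements differ; a stereocentre at a saturated ring carbon is drawn S in compound 1 and R in compound 3). Compound 4 `COc1ccc(/C=C\c2cc(OC)c(OC)c(OC)c2)cc1OCc1ccc(CN2CC[C@@H](O)C2)cc1` is not yet measured.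

In an ADME assay on HEK293 cells (Homo sapiens) for cytotoxicity, read by CCK-8 assay, with a stated time of 48 h (a higher number here means a weaker inhibitor, a lower number a stronger inhibitor), compound 1 gives only a limit of the assay, > 50000 nM. In this assay compound 2 likewise gives only a limit, > 50000 nM. In this assay, going by the values given here, compound 3 gives 27000 nM, the only number among the three. Hence the step that the two limits leave unreadable from compound 1 to compound 2 is unreadable, owing to the limit of > 50000 nM in this assay, at which 2 of the 3 values shown sit. The step of an at least 1.8-fold lower number from compound 1 to compound 3 (0.26 log units; that floor lies within the scatter) rests on (the fact that compounds 1 and 3 differ only in the configuration as drawn), and the step of an at least 1.8-fold lower number from compound 2 to compound 3 (0.26 log units; that floor lies within the scatter) is of the same floor.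

From compound 3 to compound 4 the change is hydroxy in place of carboxy on a saturated ring carbon, the same change as from compound 1 to compound 2, with the same surroundings at the place. Since that earlier step could not be read, the expectation for compound 4 leans on compound 3 giving 27000 nM. Compound 4 is therefore expected near 40000 nM, with a range from 20000 nM to 100000 nM. The estimated step is a 1.5-fold higher number from compound 3 to compound 4 (0.17 log units; within the scatter), and the measurement may well report only a limit.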

Compound 4, half-maximal inhibitory concentration: > 50000 nM
Compound 4: a limit, no number; the forecaster's own chance of this, stated with the estimate: 50%; at least 1.2-fold (0.09 log units) between middle value and limit.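

In this assay compound 4 gives only a limit of the assay, > 50000 nM, and not a number. Placing hydroxy where carboxy stood on the saturated ring carbon yields one readable step, an at least 1.8-fold higher number from compound 3 to compound 4 (0.26 log units; that floor lies within the scatter), so this pair fixes only a floor that does not rise beyond the usual variation between repeats, and it does not give the true size of the change. The same change from compound 1 to compound 2, made with that carbon in the other drawn configuration, cannot be read, and neither can the step from compound 2 to compound 4 or the one from compound 1 to compound 4, so nothing shows whether the change carries over from one configuration to the other, because so many values stop at the same point: the limit of > 50000 nM in this assay, at which 3 of the 4 values shown sit.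

The compounds shown leave open how an amino group or a methoxy group at the same saturated ring carbon would read in this assay, and whether a longer chain carrying the carboxy group would change the picture. They also leave open whether the change behaves alike on a core other than the shared one, since all four compounds carry that single core.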